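Benzyl swap on a piperidinol series against deubiquitinase

This account rests on a few compounds, and the source may have more. Where it says the series, first, only, none or still open, it means among the compounds named here.

Three compounds share a core. Compound 1 `O=c1c2cnn(-c3ccc(F)cc3)c2ncn1CC1(O)CCN(Cc2ccccc2F)CC1` was tested in an assay on Sf21 cells for inhibition of ubiquitin carboxyl-terminal hydrolase 7 (Homo sapiens), read by spectrophotometry, with stated times of 30 min and 2 h (on this read-out higher numbers stand for weaker inhibition and lower numbers for stronger inhibition), and gives 9800 nM. Compound 2 `Cc1ccc(CN2CCC(O)(Cn3cnc4c(cnn4-c4ccc(F)cc4)c3=O)CC2)cc1` was also prepared, but in this assay compound 2 gives "not determined" (no result reported), so it has no single number and gives no anchor. Compound 3 `O=c1c2cnn(-c3ccc(F)cc3)c2ncn1CC1(O)CCN(Cc2ccc(Cl)cc2Cl)CC1` differs from compound 2 by 2,4-dichlorophenyl in place of 4-methylphenyl on a saturated chain carbon bound to an amine nitrogen in a ring. Among the compounds with values here, with no measured step between neighbours, the size of the change in this assay from compound 2 to compound 3 cannot be judged beyond the scatter, and only the weak result of compound 1 offers guidance. Compound 3 is expected to give about 6000 nM, estimated within 1500 nM to 25000 nM.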

Compound 3, half-maximal inhibitory concentration: 3300 nM
Estimate against measurement, compound 3: 1.8-fold (0.26 log units) above; measured number inside the range.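

With 2,4-dichlorophenyl in place of 2-fluorophenyl on a saturated chain carbon bound to an amine nitrogen in a ring, this assay shows a 3.0-fold lower number from compound 1 to compound 3 (0.47 log units; beyond the scatter) and so gives the series its first readable step, showing that the number responds to a change at this position. The step from compound 2 to compound 3 cannot be read, since compound 2 has no number. Nothing measured here accounts for the change.

Going by these compounds, whether a pyridine ring or a methoxy-substituted phenyl at this position would move the number further remains open. So does how much of the step belongs to either chlorine alone.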